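Cyclopropyl ketones and chalcones: cytotoxicity on Vero cells

This account rests on a few compounds, and the source may have more. Where it says the series, first, only, none or still open, it means among the compounds named here.

Measured compounds:
compound 1 `CN1CCN(c2ccc(C(=O)/C=C/c3ccc(Cl)cc3)cc2)CC1` gives 102 ug/mL in an ADME assay on Vero cells (Chlorocebus sabaeus) for cytotoxicity, with a stated time of 72 h; on this read-out higher numbers stand for lower toxicity in this test and lower numbers for higher toxicity in this test
compound 2 `O=C(/C=C/c1ccc(Cl)cc1)c1ccc(NCc2ccco2)cc1` gives 404 ug/mL in this assay
compound 3 `CCCCN(CCCC)c1ccc(C(=O)C2CC2c2ccc(Cl)cc2)cc1` gives 431 ug/mL in this assay

Compound 3 shows the highest of the three numbers in this assay; its gap to compound 2 is within the scatter, and only compound 1 sits clearly lower. Compound 4 `O=C(c1ccc(NCCn2ccnc2)cc1)C1CC1c1ccc(Cl)cc1` is the next member, differing from compound 3 at one position: (2-(1H-imidazol-1-yl)ethyl)amino in place of dibutylamino on an aromatic carbon, on an aromatic carbon of a six-membered aromatic ring of carbon only, para to a large group.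

Within the data shown here, one measured step bears on this change, the exchange at the same aromatic carbon on the shared core of compound 1: a 4.0-fold higher number from compound 1 to compound 2 (0.60 log units; beyond the scatter). There the cyclic amino group with a second nitrogen gave the lowest number of the set, while the secondary amine carrying a heteroaryl-methyl group gave a number close to that of compound 3. Compound 4 carries a secondary amine, like compound 2, but also a second ring nitrogen pair reminiscent of compound 1. Among the measured compounds shown here, the expectation for compound 4 is therefore a modest fall from compound 3 in this assay, a 2.2-fold lower number from compound 3 to compound 4 (0.33 log units; beyond the scatter), with wide uncertainty because the only analogous step a 4.0-fold higher number from compound 1 to compound 2 (0.60 log units; beyond the scatter) sits on a different core. Compound 4 is estimated at 200 ug/mL, within 80 ug/mL to 450 ug/mL.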

Compound 4, half-maximal cytotoxic concentration: 243 ug/mL
Beside the measured number, compound 4's estimate is 1.2-fold (0.08 log units) below it, within the range that was stated.
By their numbers in this assay, from the lowest: compound 1; then compounds 4, 2 and 3 (each within the scatter of the next).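

In this assay, (2-(1H-imidazol-1-yl)ethyl)amino in place of dibutylamino on this aromatic carbon gives a 1.8-fold lower number from compound 3 to compound 4 (0.25 log units; within the scatter), although the entering group brings a five-membered aromatic ring and a hydrogen-bond donor that dibutylamino lacks. On the core of compound 3, these two amino groups are therefore not told apart by this read-out, whereas the exchange on the core of compound 1, a 4.0-fold higher number from compound 1 to compound 2 (0.60 log units; beyond the scatter), lies beyond the scatter. Nothing available accounts for either outcome.

Still open, as far as these compounds go, is whether a carboxylic acid or a simple primary amine at this aromatic carbon would also stay within the scatter of compound 3. From the compounds shown here alone, it is equally open whether a longer chain leading to the imidazole would do so, or how (2-(1H-imidazol-1-yl)ethyl)amino reads on the chalcone core.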